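The source may hold more compounds than are shown below. What is called first, only, known or untested is meant among the compounds shown, and "the series" means these compounds.

Compound 2, `CNCc1cn(S(=O)(=O)c2cncc(C)c2)c(-c2cccnc2F)c1F`, is the lower of two numbers in a functional assay on the whole organism (strain Jcl:Sprague-Dawley) for inhibition, with Rattus norvegicus as the target, with stated times of 3 min and 3 h, at a dose of 1 mg/kg by the intravenous route (a higher number here means more inhibition at the dose given (going by the name of the read-out), a lower number less inhibition), where compound 2 gives 87%. Compound 1, `CNCc1cn(S(=O)(=O)c2ccccn2)c(-c2cccnc2F)c1F`, gives 95% in this assay, and the change a number 8 percentage points lower from compound 1 to compound 2 (within the scatter) lies within the scatter. Compound 3, `CNCc1cn(S(=O)(=O)c2ccc(C)nc2)c(-c2cccnc2F)c1F`, differs from compound 2 only in where the methyl group sits: 6-methylpyridin-3-yl in place of 5-methylpyridin-3-yl on a sulfonyl sulfur. Among the compounds with values here, the one measured step replaced a whole ring on the sulfonyl sulfur and barely moved the number, so moving a methyl within a ring is expected to stay within the scatter, with a number 2 percentage points lower from compound 2 to compound 3 (within the scatter). Compound 3 is therefore estimated at 85%, between 70% and 95%.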

Compound 3, a percentage reported as inhibition, in the whole organism at one dose (the size of the read-out at that dose, not a potency) in the Rattus norvegicus assay: 97%
Beside the measured number, compound 3's estimate is 12 percentage points below it, outside the stated range (above it).
By their numbers in the Rattus norvegicus assay, from the lowest: compounds 2, 1 and 3 (each within the scatter of the next).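

In the Rattus norvegicus assay moving the methyl group gives a number 10 percentage points higher from compound 2 to compound 3 (within the scatter) and exchanging the ring gives a number 2 percentage points higher from compound 1 to compound 3 (within the scatter) so all three rings on this sulfonyl sulfur stand within the scatter of one another. In a physicochemical assay for lipophilicity, read by HPLC, at pH 7.4 (on this read-out higher numbers stand for higher lipophilicity and lower numbers for lower lipophilicity), compound 2 gives 0.61 and compound 3 gives 0.62 with a number 0.01 log units higher from compound 2 to compound 3 (within the scatter) so the place of the methyl group registers in neither read-out. Nothing available explains these numbers.

As far as these compounds go, whether this sulfonyl sulfur would keep the inhibition with an amine or a carboxylic acid on the ring, or with a phenyl ring instead of a pyridine, stays open.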